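Removing the benzyl chloro of compound 1

The source may hold more compounds than are shown below. What is called first, only, known or untested is meant among the compounds shown, and "the series" means these compounds.

Compound 1 `O=C(CSc1nc2ccc(NC(=O)c3ccc(Cl)cc3)cc2s1)NCc1ccc(Cl)cc1` is the starting point of this series. In a functional assay on MCF7 cells (Homo sapiens) for cytotoxicity, read by MTT assay, with a stated time of 48 h (on this read-out higher numbers stand for weaker inhibition and lower numbers for stronger inhibition), compound 1 gives 29300 nM, the lowest of the two numbers recorded, with compound 2 `O=C(CSc1nc2ccc(NC(=O)c3ccccc3)cc2s1)NCc1ccc(Cl)cc1` standing nearest at 33700 nM. Compound 3 `O=C(CSc1nc2ccc(NC(=O)c3ccc([N+](=O)[O-])cc3)cc2s1)NCc1ccc(Cl)cc1` reaches only the limit (the limit of > 100000 nM in this assay, at which 1 of the 3 values shown sits), and in this assay compound 3 is reported as > 100000 nM, a limit and not a number.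

The step to compound 4 `O=C(CSc1nc2ccc(NC(=O)c3ccc(Cl)cc3)cc2s1)NCc1ccccc1` is hydrogen in place of chloro on an aromatic carbon; cut one bond further out, it reads 4-chlorobenzyl to benzyl.

Among the measured compounds shown here, two measured steps bear on it. The same exchange of chloro for hydrogen on the other six-membered ring of carbon gives a 1.2-fold higher number from compound 1 to compound 2 (0.06 log units; within the scatter), which stays within the scatter. The exchanges that moved the number beyond the scatter were an at least 3.4-fold higher number from compound 1 to compound 3 (0.53 log units; beyond the scatter) and an at least 2.9-fold higher number from compound 2 to compound 3 (0.47 log units; beyond the scatter), both introducing nitro rather than removing chloro. For the measured compounds named here, nothing among the measured compounds suggests that losing a chloro changes the number in this assay beyond the scatter, so for compound 4 the expected step is a 1.2-fold higher number from compound 1 to compound 4 (0.08 log units; within the scatter), essentially none. Compound 4 is therefore estimated at 35000 nM, with a range from 15000 nM to 85000 nM.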

Compound 4, half-maximal inhibitory concentration: 25900 nM
Beside the measured number, compound 4's estimate is 1.4-fold (0.13 log units) above it, and the stated range covers the measured number.
By their numbers in this assay, from the lowest: compounds 4, 1 and 2 (each within the scatter of the next). At a limit, above all of these: compound 3.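

Among the compounds shown here, compound 4 is the first change at the 4-chlorobenzyl end of the series, and in this assay the exchange gives a 1.1-fold lower number from compound 1 to compound 4 (0.05 log units; within the scatter), so losing this chloro, para to a large group, leaves the number within the scatter. Until now, removal of a chloro had been read only on the other six-membered ring of carbon, as a 1.2-fold higher number from compound 1 to compound 2 (0.06 log units; within the scatter), and these two steps now show that the same exchange stays within the scatter at both places, although neither step says anything about exchanges other than chloro to hydrogen. Nothing measured among the compounds shown explains why the number holds at this position.

As far as these compounds go, it remains open whether this position accepts only a chloro or a hydrogen, or whether the number would also hold with a nitro, as on the other ring it did not, or with a methoxy, an amine or a carboxylic acid. From the compounds shown here alone, it is equally open whether a longer chain between the amide nitrogen and this ring, in place of the benzyl, would leave the number where it stands.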